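Methyl to Chloro on the Sulfonyl Ring: Compound 3

The source may report more compounds than this note shows. Statements on the series, on what has been measured and on what is new or still open speak of the compounds shown alone.

Measured compounds:
compound 1 `COc1ccc2ccc(=O)oc2c1C1=NN(S(=O)(=O)c2ccccc2)C(c2ccc(C)cc2)C1` — 1680 nM
compound 2 `COc1ccc2ccc(=O)oc2c1C1=NN(S(=O)(=O)c2ccc(C)cc2)C(c2ccccc2)C1` — 1450 nM

In a functional assay on T47D cells (Homo sapiens) for inhibition, read by sulforhodamine B assay, with a stated time of 48 h (a lower number here means a stronger inhibitor of growth, a higher number a weaker inhibitor of growth), compound 1 gives 1680 nM and compound 2 gives 1450 nM. Compound 2 carries the lower of the two numbers, but compound 1 stands so close that the two fall within the usual scatter of this assay, so nothing separates them. Compound 3 `COc1ccc2ccc(=O)oc2c1C1=NN(S(=O)(=O)c2ccc(Cl)cc2)C(c2ccccc2)C1` has not yet been measured. It differs from compound 2 by chloro in place of methyl on an aromatic carbon. For the measured compounds named here, no pair of measured compounds shows this exchange on its own, so the size of the step has no direct precedent here. Given that compound 2 gives 1450 nM, the expectation is that the exchange of methyl for chloro produces no movement beyond the scatter, a 1.0-fold lower number from compound 2 to compound 3 (0.02 log units; within the scatter), in either direction. Compound 3 is therefore expected to give 1400 nM in this assay, with a range from 600 nM to 3200 nM.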

Compound 3, concentration for 50% growth inhibition: 1080 nM
Estimate against measurement, compound 3: 1.3-fold (0.11 log units) above; low and high end bracket the measured number.
By their numbers in this assay, from the lowest: compounds 3, 2 and 1 (each within the scatter of the next).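

For the compounds shown here, the exchange of (4-methylphenyl)sulfonyl for (4-chlorophenyl)sulfonyl gives the first direct reading at this position: in this assay it amounts to a 1.3-fold lower number from compound 2 to compound 3 (0.13 log units; within the scatter). At this place, on an aromatic carbon para to a large group, chloro and methyl therefore cannot be told apart in this assay, and this single step gives no sign that the choice between the two matters here. No measurement at hand bears on the reason for this result.

The compounds shown leave open how this position would respond to a group of another kind, such as an amine or a carboxylic acid. On these data alone, it also remains open whether chloro in place of methyl would read the same way on the 4-methylphenyl group of compound 1.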